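The source may report more compounds than this note shows. Statements on the series, on what has been measured and on what is new or still open speak of the compounds shown alone.

Of the compounds shown here, two have been tested in an ADME assay on Caco-2 cells (Homo sapiens) for permeability, in the apical to basolateral direction; a lower number here means that the compound crosses the layer more slowly, a higher number that the compound crosses the layer faster. Compound 1, `Cn1cncc1CN1CC(N(CC2CCN(C(=O)Nc3ccc(Br)cc3)CC2)S(=O)(=O)c2ccccn2)Cc2cc(C#N)ccc21`, crosses slowly, giving 0.6 10^-6 cm/s in this assay. Compound 2, `Cn1cncc1CN1CC(N(CCn2cccc2)S(=O)(=O)c2ccccn2)Cc2cc(C#N)ccc21`, gives 12.4 10^-6 cm/s, the higher of the two numbers, and its distance from compound 1 lies well beyond the usual scatter of the measurement. Compound 3, `CCCC(=O)N1CCC(CN(C2Cc3cc(C#N)ccc3N(Cc3cncn3C)C2)S(=O)(=O)c2ccccn2)CC1`, has not yet been measured. It differs from compound 2 in one place: 1-(propylcarbonyl)piperidin-4-yl in place of (1H-pyrrol-1-yl)methyl on a saturated chain carbon bound to a sulfonamide nitrogen. Among the compounds with values here, since no two measured compounds differ by exactly this change, no measured step can be quoted for it, and what follows rests on compounds 1 and 2 alone. Compound 3 is expected to sit between its two neighbours, with a step from compound 2 of a 3.5-fold lower number from compound 2 to compound 3 (0.55 log units; beyond the scatter), a drop beyond the scatter but smaller than the gap between compounds 1 and 2. For compound 3 the estimated value in this assay is 3.5 10^-6 cm/s, with a likely range from 1.2 10^-6 cm/s to 9 10^-6 cm/s.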

Compound 3, apparent permeability: 0.5 10^-6 cm/s
Compound 3: middle estimate off by 7.0-fold (0.85 log units), on the high side; measured number outside the range, below it.
By their numbers in this assay, from the lowest: compounds 3 and 1 (each within the scatter of the next); then compound 2.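

In this assay, 1-(propylcarbonyl)piperidin-4-yl in place of (1H-pyrrol-1-yl)methyl on a saturated chain carbon bound to a sulfonamide nitrogen gives a 25-fold lower number from compound 2 to compound 3 (1.39 log units; beyond the scatter), so this position responds strongly to this change. The far end of the larger group shifts the number much less: propyl in place of (4-bromophenyl)amino on a carbonyl carbon gives a 1.2-fold lower number from compound 1 to compound 3 (0.08 log units; within the scatter), which is within the scatter, so the low number is not tied to the bromophenyl urea of compound 1. Nothing measured here gives a reason for the large step.

As far as these compounds go, it remains open whether the drop goes with the piperidine ring itself or with the carbonyl group on it. A cyclohexyl ring or a plain butyl chain at this position would help separate those two parts, and a free piperidine amine would test the carbonyl group directly.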